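Notes on tert-butyl in place of methyl

The compounds below may be only part of what the source reports. "The series", "measured", "known", "first", "only" and "open" are said of these compounds alone.

Measured so far:
compound 1 `Nc1nc(Cl)c(-c2nccs2)c(N[C@@H]2C[C@H](CO)[C@@H](O)[C@H]2O)n1`: > 25000 nM
compound 2 `CNc1nc(C)c(-c2nc3ccccc3s2)c(N[C@@H]2C[C@H](CO)[C@@H](O)[C@H]2O)n1`: > 25000 nM

Both entries come from an ADME assay on cells (Homo sapiens) for cytotoxicity, read by polymerase chain reaction, with a stated time of 3 days; on this read-out lower numbers stand for higher toxicity in this test and higher numbers for lower toxicity in this test. Compound 1 gives > 25000 nM, which is a limit of the assay and not a number. Compound 2 gives > 25000 nM, which is also a limit and not a number. Within the data shown here, compound 2 therefore has no numeric position, and the only evidence is the limit of > 25000 nM in this assay, at which 2 of the 2 values shown sit.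

The next compound is compound 3 `Cc1nc(NC(C)(C)C)nc(N[C@@H]2C[C@H](CO)[C@@H](O)[C@H]2O)c1-c1nc2ccccc2s1`, with tert-butyl in place of methyl on a nitrogen on an aromatic ring. Among the measured compounds shown here, no measured pair shows this change, so its effect in this assay can only be estimated. The expectation is no step beyond the scatter, with neither direction favoured, and a further report as a limit is the likeliest outcome. The expected step is a number no higher from compound 2 to compound 3 (the limit leaves the size open), an estimate only. For compound 3 the estimated value is 25000 nM, with an expected range of 10000 nM to 50000 nM.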

Compound 3, half-maximal cytotoxic concentration: 12000 nM
Beside the measured number, compound 3's estimate is 2.1-fold (0.32 log units) above it; low and high end bracket the measured number.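

In this assay, among these compounds, tert-butyl in place of methyl on a nitrogen on an aromatic ring gives an at least 2.0-fold lower number from compound 2 to compound 3 (0.31 log units; beyond the scatter), so this position is the first where a change can be read as a step beyond the scatter. Compound 3 gives 12000 nM, the first entry that is a number and not a limit, which shows that the group on this nitrogen can move the read-out towards higher toxicity in this test, at least in this one pair on the shared core. The full size of the step stays unfixed, since its starting point is a limit and not a number: the limit of > 25000 nM in this assay, at which 2 of the 3 values shown sit.

One pair cannot tell whether the read-out moves gradually from methyl to tert-butyl, and ethyl, isopropyl or a cyclic group such as cyclopropyl on the same nitrogen would be needed to settle that. Among the compounds shown here, it also stays open whether a chain ending in a hydroxyl or an amine at this place would keep the read-out at the limit, and whether the tert-butyl step carries over to cores with another group in place of the one shared by compound 2 and compound 3.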